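Adding a methoxy group to a shared anilino-pyrimidine core

The source may hold more compounds than are shown below. What is called first, only, known or untested is meant among the compounds shown, and "the series" means these compounds.

Of the compounds shown here, three of one family have been tested in a functional assay on MDA-MB-231 cells (Homo sapiens) for inhibition, read by CCK-8 assay, with a stated time of 48 h; a lower number here means a stronger inhibitor of growth, a higher number a weaker inhibitor of growth. Compound 1, with the structure `Cc1ccc(Nc2ncc(Cl)c(Nc3ccccc3C)n2)cc1`, gives only a limit in this assay, reported as > 100000 nM, and not a number. Compound 2, with the structure `Cc1ccccc1Nc1nc(Nc2ccc(N3CCCCC3)cc2)ncc1Cl`, gives 19900 nM. The one single-site step among these is an at least 5.0-fold lower number from compound 1 to compound 2 (0.70 log units; beyond the scatter). Compound 3, with the structure `CN1CCN(c2ccc(Nc3ncc(Cl)c(Nc4ccccc4)n3)nc2)CC1`, gives 37400 nM, the highest of the two numbers shown; its nearest neighbour is compound 2, whose number is lower by an amount that stays within the scatter of repeated measurements, so the two cannot be ranked.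

Compound 4, with the structure `COc1ccc(Nc2nc(Nc3ccc(N4CCN(C)CC4)cn3)ncc2Cl)cc1`, is not yet measured. It differs from compound 3 by methoxy in place of hydrogen on an aromatic carbon. Within the data shown here, no measured step concerns a methoxy group or this position; the only step at hand concerns a piperidin-1-yl in place of methyl on an aromatic carbon, a different group at a different site, and so it gives no direct guidance. The expectation is therefore a step of a 1.2-fold lower number from compound 3 to compound 4 (0.10 log units; within the scatter), that is, none beyond the scatter. Compound 4 is estimated to give 30000 nM in this assay, with a range from 10000 nM to 100000 nM.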

Compound 4, concentration for 50% growth inhibition: 8020 nM
Estimate against measurement, compound 4: 3.7-fold (0.57 log units) above; measured number outside the range, below it.
By their numbers in this assay, from the lowest: compound 4; then compounds 2 and 3 (each within the scatter of the next). At a limit, above all of these: compound 1.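

In this assay, the result gives the first measured view of the ring that carries the anilino nitrogen: methoxy in place of hydrogen, on an aromatic carbon para to a large group, gives a 4.7-fold lower number from compound 3 to compound 4 (0.67 log units; beyond the scatter). The earlier single-site step, an at least 5.0-fold lower number from compound 1 to compound 2 (0.70 log units; beyond the scatter), concerned a different group at a different site, so it said nothing about this carbon. The new step shows that this position is not silent, since one small change here, phenyl to 4-methoxyphenyl, moves the number by more than repeated measurements would, although nothing shown here bears on why it does so.

The compounds shown leave open whether this step belongs to methoxy itself or would appear with other groups on the same carbon, such as a hydroxyl group, an amine, a fluorine atom or the longer ethoxy chain. They also leave open whether methoxy would give a step of similar size at another carbon of this ring, or on the piperidin-1-yl-bearing compound 2.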